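This account rests on a few compounds, and the source may have more. Where it says the series, first, only, none or still open, it means among the compounds named here.

Three related compounds have been tested for growth inhibition of a colon cancer cell line, and a fourth awaits its result. Compound 1 `COc1ccc(/C=C/C(=O)/C=C/c2ccc(OCc3cn(CCCCOc4cc(=O)oc5ccccc45)nn3)c(OC)c2)cc1OC` and compound 2 `COc1cc(/C=C/C(=O)/C=C/c2cc(OC)c(OC)c(OC)c2)ccc1OCc1cn(CCCCOc2cc(=O)oc3ccccc23)nn1` share a core and differ at a single point: hydrogen in place of methoxy on an aromatic carbon. In a functional assay on COLO 205 cells (Homo sapiens) for inhibition, read by sulforhodamine B assay, with a stated time of 48 h, tested at 50 uM (a lower number here means less inhibition of growth, a higher number more inhibition of growth at the concentration tested), compound 2 gives 60%, while compound 1 gives 53%, so a number 7 percentage points lower from compound 2 to compound 1 (within the scatter). Compound 3 `COc1ccc(/C=C/C(=O)/C=C/c2ccc(OCc3cn(CCCOc4cc(=O)oc5ccccc45)nn3)c(OC)c2)cc1` carries a different core; the difference between the two cores is not broken down here. In this assay compound 3 gives 53%, level with compound 1 and, together with it, the lowest of the three numbers, though all three sit within the usual scatter of one another.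

Compound 4 `COc1cc(/C=C/C(=O)/C=C/c2ccccc2)ccc1OCc1cn(CCCOc2cc(=O)oc3ccccc23)nn1` is compound 3 with one change: hydrogen in place of methoxy on an aromatic carbon. This is the same kind of change as from compound 2 to compound 1, though the surroundings differ: there the spot was ortho to a methoxy group, meta to a large group and meta to a methoxy group; here it is para to a large group. Because the earlier step was a number 7 percentage points lower from compound 2 to compound 1 (within the scatter), compound 4 is expected to show a number 5 percentage points lower from compound 3 to compound 4 (within the scatter), giving an estimated 48% with a likely range from 33% to 63%.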

Compound 4, percent growth inhibition at one concentration: 43%
Compound 4: the middle estimate sits 5 percentage points above what was measured; measured number inside the range.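

In this assay, exchanging methoxy for hydrogen para to a large group, the change from 4-methoxyphenyl to phenyl, gives a number 10 percentage points lower from compound 3 to compound 4 (within the scatter). Set beside the earlier case of the same exchange, the two steps agree: the same change on two cores in this assay, a number 7 percentage points lower (within the scatter) from compound 2 to compound 1 and a number 10 percentage points lower (within the scatter) from compound 3 to compound 4, 3 percentage points apart, within the scatter of two such steps This shows that, on these two cores, the exchange gives steps that cannot be told apart, but it does not show that the exchange itself alters growth inhibition, since each step lies within the scatter, and two pairs, with the change at different places on the ring, make no rule for the whole series.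

The compounds shown leave open whether a different group on this ring, such as an amine or a chlorine atom in place of the methoxy, would give a step beyond the scatter. Also open, going by these compounds, is whether the exchange would give a similar step on a core with a longer chain between the triazole and the far ring system.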